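Adding a Second Chloro Near the Ketone of Compound 1

This account rests on a few compounds, and the source may have more. Where it says the series, first, only, none or still open, it means among the compounds named here.

Measured compounds:
compound 1 `CC(C)(C)Cc1csc(N)c1C(=O)c1cccc(Cl)c1` gives 2%
compound 2 `CC(C)(C)Cc1c(-c2ccc(Cl)cc2)sc(N)c1C(=O)c1ccc(Cl)cc1` gives 1%
compound 3 `CC(C)(C)Cc1c(-c2ccc(Cl)c(Cl)c2)sc(N)c1C(=O)c1ccc(Cl)cc1` gives 1%

All three were tested in an assay on CHO cells for displacement of a labelled ligand from adenosine receptor A1 (Homo sapiens), read by scintillation counting, tested at 10 uM; on this read-out lower numbers stand for less inhibition and higher numbers for more inhibition at the one concentration tested (going by the name of the read-out). Compound 1 gives 2%, compound 2 gives 1% and compound 3 gives 1%; these numbers lie within the scatter of one another, so none can be ranked above the others. Compound 1 and compound 2 have different cores, and that difference is not broken down here.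

Compound 2 and compound 3 differ by one change, (chloro in place of hydrogen on an aromatic carbon), and the step it made was no change at the digits printed from compound 2 to compound 3 (within the scatter).

The unmeasured compound 4 `CC(C)(C)Cc1csc(N)c1C(=O)c1ccc(Cl)c(Cl)c1` differs from compound 1 by chloro in place of hydrogen on an aromatic carbon. This is the same kind of change, but the surroundings differ: in compound 3 the new chloro sits meta to a large group, in compound 4 para to a large group.

Because no change at the digits printed from compound 2 to compound 3 (within the scatter) showed no movement, the same kind of change is expected to give no change at the digits printed from compound 1 to compound 4 (within the scatter). Compound 4 is therefore expected to read 2%, with a likely range from 0% to 10%.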

Compound 4, a percentage reported as inhibition, at one concentration (the size of the read-out at that concentration, not a potency): 1%
The estimate for compound 4 lay 1 percentage points above the measured number; low and high end bracket the measured number.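

In this assay, chloro in place of hydrogen on the core of compound 1 gave a number 1 percentage points lower from compound 1 to compound 4 (within the scatter). Set beside the earlier step, the change carried from one core to the other with no visible difference: the same change on two cores in this assay, no change at the digits printed (within the scatter) from compound 2 to compound 3 and a number 1 percentage points lower (within the scatter) from compound 1 to compound 4, 1 percentage points apart, within the scatter of two such steps All four compounds show very little inhibition, however, and two steps without movement say nothing about how the change would carry over to a compound with clear inhibition, or to cores beyond these two.

On these data alone, it remains open whether a different group in the same place, such as a methoxy group, an amine or a carboxylic acid, would give a different reading. As far as these compounds go, it is also open whether any change to this series can produce clear inhibition at this receptor.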